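The source may hold more compounds than are shown below. What is called first, only, known or untested is meant among the compounds shown, and "the series" means these compounds.

Measured in an ADME assay on HepG2 cells (Homo sapiens) for cytotoxicity, with a stated time of 72 h; on this read-out higher numbers stand for an effect only at larger amounts of compound and lower numbers for an effect already at smaller amounts:
Compound 1 `Cc1cc(NC(=O)Nc2ccccc2C(C)(C)C)c2ccccc2n1`: > 25000 nM
Compound 2 `Cc1cc(NC(=O)Nc2ncccc2C)c2ccccc2n1`: > 25000 nM

For the measured compounds named here, neither entry is a number, and no measured step connects the two compounds. Compound 2 reads > 25000 nM, which is a limit of the assay. The same holds for the pair as a whole: the limit of > 25000 nM in this assay, at which 2 of the 2 values shown sit.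

The next compound, compound 3 `Cc1cc(NC(=O)Nc2ccccc2F)c2ccccc2n1`, has not yet been measured in this assay. It carries 2-fluorophenyl in place of 3-methylpyridin-2-yl on an amide-type nitrogen, a change counted as 2-fluorophenyl in place of 3-methylpyridin-2-yl on an amide-type nitrogen. The rest of the structure stays as in compound 2. Going by the values given here, no measured pair shows what such a swap does in this assay, so the expectation rests on the two limits alone.

Compound 1 reads > 25000 nM, which is also a limit. The expected change, a number no higher from compound 2 to compound 3 (the limit leaves the size open), is estimated to lie within the usual scatter, with no direction favoured. The most likely outcome is that the assay again reports only a limit. For compound 3 the estimated value is 25000 nM, with an expected range from 12000 nM to 50000 nM.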

Compound 3, half-maximal effective concentration: > 25000 nM
Compound 3: only a limit was reported (the forecaster's own chance of this, stated with the estimate: 80%); the middle value sits exactly at the limit.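

The steps from compound 1 and from compound 2 to compound 3 cannot be read, since all three compounds return only a limit: the limit of > 25000 nM in this assay, at which 3 of the 3 values shown sit.

The compounds shown leave open how far apart compounds 1, 2 and 3 really lie in this assay, and whether swapping these groups makes any difference there at all.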